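Swapping thiophen-3-yl for phenyl in compound 1

A few compounds are considered here, and "the series" means these few. Any claim that something is new, unique, unknown or untested is made for them only; others in the source may bear on it.

In an in vitro ADME assay on microsomes from liver (Homo sapiens) for metabolic stability (a higher number here means faster removal of the compound, a lower number slower removal), compound 1 `O=C(Nc1cccnc1-c1ccsc1)N1CCN2C(=O)N([C@H]3C[C@@H]3c3ccccc3)C(=O)[C@@H]2C1` gives 40000 mL.min-1.g-1. Compound 2 `O=C(Nc1ccnn1-c1cccc(F)c1)N1CCN2C(=O)N([C@H]3C[C@@H]3c3ccccc3)C(=O)[C@@H]2C1`, built on the same core, gives 45000 mL.min-1.g-1, and compound 3 `N#Cc1cc(Cl)c(NC(=O)N2CCN3C(=O)N([C@H]4C[C@@H]4c4ccccc4)C(=O)[C@@H]3C2)c(Cl)c1`, also on that core, gives 66000 mL.min-1.g-1. Compound 1 therefore stands in a tight group of numbers: neither of the other two compounds is separated from it by more than the usual scatter of repeat measurements.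

Compound 4 `O=C(Nc1cccnc1-c1ccccc1)N1CCN2C(=O)N([C@H]3C[C@@H]3c3ccccc3)C(=O)[C@@H]2C1` has not yet been measured, and it differs from compound 1 in one place: phenyl in place of thiophen-3-yl on an aromatic carbon. The change is phenyl in place of thiophen-3-yl on an aromatic carbon, next to the ring nitrogen.

Going by the values given here, no measured pair shows this exact swap, so the evidence is indirect. Among the compounds with values here, the one measured step that bears on it is a 1.7-fold higher number from compound 1 to compound 3 (0.22 log units; within the scatter). That step replaces the entire 2-(thiophen-3-yl)pyridin-3-yl group, a much larger edit than the exchange of one ring, and it stays within the scatter. A step beyond the scatter is therefore not expected in this assay here, and the estimated step is a 1.1-fold higher number from compound 1 to compound 4 (0.05 log units; within the scatter). Compound 4 is estimated at 45000 mL.min-1.g-1, with an expected range from 25000 mL.min-1.g-1 to 80000 mL.min-1.g-1.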

Compound 4, intrinsic clearance in microsomes: 45000 mL.min-1.g-1
Compound 4: the middle estimate sits on the measured number at the digits printed, within the range that was stated.
By their numbers in this assay, from the lowest: compounds 1, 2, 4 and 3 (each within the scatter of the next).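

In this assay the exchange of thiophen-3-yl for phenyl gives a 1.1-fold higher number from compound 1 to compound 4 (0.05 log units; within the scatter) and so isolates a single ring on an aromatic carbon next to the ring nitrogen, whereas the earlier step replaced the whole group at once. At this place, a five-membered aromatic ring with 5 heavy atoms, one of them sulfur, and a six-membered ring of carbon only give numbers that cannot be told apart, so this pair offers no sign that the sulfur atom or the hydrogen-bond acceptor counted on the leaving ring matters for the read-out. No separate measurement is available to explain this result.

On these data alone, compounds 1 and 4 both carry an unsubstituted aromatic ring at this place, so it remains open what a saturated amine such as piperidine, or a phenyl bearing a carboxylic acid, would do here. Every step shown so far lies within the scatter, which leaves open whether any group at this place can produce a clear step in this assay at all.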